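The source may hold more compounds than are shown below. What is called first, only, known or untested is meant among the compounds shown, and "the series" means these compounds.

In an ADME assay on HEp-2 cells (Homo sapiens) for cytotoxicity (a lower number here means that less compound is tolerated, a higher number that more compound is tolerated), compound 1 `CC(C)CCn1c(Cn2c(=O)n(C(C)C)c3ccccc32)nc2cc(CF)ccc21` gives 37300 nM. Going by the values given here, the only other measured compound, compound 2 `CC(C)CCn1c(Cn2c(=O)n(C(C)C)c3ccccc32)nc2ccc(C(N)=O)cc21`, gives 49900 nM, which places compound 1 within the scatter of compound 2. Compound 3 `CC(C)CCn1c(Cn2c(=O)n(C(C)C)c3ccccc32)nc2cc(C(N)=O)ccc21` has not yet been measured. It departs from compound 1 at a single place, with carbamoyl in place of fluoromethyl on an aromatic carbon. Among the compounds with values here, no step between measured compounds that differ in one place is available to size this change. Within the data shown here, the only guide is that compound 2, at 49900 nM, lies within the scatter of compound 1, so no step beyond the scatter is expected in this assay, in either direction. The expected change is small, a 1.2-fold higher number from compound 1 to compound 3 (0.08 log units; within the scatter). For compound 3 the estimated value is 45000 nM, with an expected range from 20000 nM to 100000 nM.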

Compound 3, half-maximal cytotoxic concentration: 23400 nM
Estimate against measurement, compound 3: 1.9-fold (0.28 log units) above, within the range that was stated.
By their numbers in this assay, from the lowest: compounds 3, 1 and 2 (each within the scatter of the next, the first and the last beyond it).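

Replacing fluoromethyl with carbamoyl on this aromatic carbon, meta to a fused ring and para to a fused ring, gives in this assay the step of a 1.6-fold lower number from compound 1 to compound 3 (0.20 log units; within the scatter) and so stays within the scatter. At this place, this assay does not tell the two groups apart, even though carbamoyl brings a hydrogen-bond donor and a hydrogen-bond acceptor that fluoromethyl lacks. Compound 3 gives 23400 nM and compound 2 gives 49900 nM with the same carbamoyl on a different aromatic carbon, and this pair alone among the three lies beyond the scatter.

Nothing available explains these numbers.
Going by these compounds, whether an amine, a carboxylic acid or a longer chain on this carbon would also stay within the scatter of compound 1 remains open.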